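Swapping bromo for amino on the shared core

This account rests on a few compounds, and the source may have more. Where it says the series, first, only, none or still open, it means among the compounds named here.

Compound 1 `O=C1Nc2ccc(Cl)cc2/C1=C\c1ccco1` gives 14700 nM
Compound 2 `O=C1Nc2ccc(Br)cc2/C1=C\c1ccco1` gives 9840 nM

Both compounds were tested in a functional assay on MCF7 cells (Homo sapiens) for inhibition, read by MTT assay, with a stated time of 48 h (a higher number here means a weaker inhibitor, a lower number a stronger inhibitor), and their numbers sit close together: compound 2 (9840 nM) lies within the scatter of compound 1 (14700 nM), so the two cannot be ranked. The next compound, compound 3 (`Nc1ccc2c(c1)/C(=C\c1ccco1)C(=O)N2`), has amino in place of bromo on an aromatic carbon. Within the data shown here, only one measured step bears on this change (a 1.5-fold lower number from compound 1 to compound 2 (0.17 log units; within the scatter)), with bromo in place of chloro on an aromatic carbon. Among the measured compounds shown here, that step exchanges one halogen for another, and no measured compound carries amino, so the data give no firm direction. No change beyond the scatter is expected, though with wide uncertainty, and the estimated step is small (a 1.5-fold higher number from compound 2 to compound 3 (0.18 log units; within the scatter)). Compound 3 is expected at 15000 nM (estimated range 5000 nM to 45000 nM).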

Compound 3, half-maximal inhibitory concentration: 15500 nM
Compound 3: middle estimate off by 1.0-fold (0.01 log units), on the low side; the range from low to high includes it.
By their numbers in this assay, from the lowest: compounds 2, 1 and 3 (each within the scatter of the next).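

In this assay, amino in place of bromo gives a 1.6-fold higher number from compound 2 to compound 3 (0.20 log units; within the scatter), and amino in place of chloro gives a 1.1-fold higher number from compound 1 to compound 3 (0.02 log units; within the scatter), so amino cannot be ranked against either halogen at this position. Among these compounds, the earlier step only exchanged one halogen for another, whereas this change also alters the counts of hydrogen-bond donors and acceptors on the aromatic carbon, and still no step goes beyond the scatter. No measurement shown here offers an explanation for this result.

The compounds shown leave open whether any group at this position can move the number beyond the scatter, since all three substituents are single-atom groups. A carboxylic acid, a methoxy group or a longer chain on the same aromatic carbon would test whether larger groups behave the same way.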